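Urea in place of amide at a fixed methoxychlorophenyl core

This account rests on a few compounds, and the source may have more. Where it says the series, first, only, none or still open, it means among the compounds named here.

The series shares one core, shown in compound 1 `COc1cc(Cl)cc(-c2nn(-c3cccc(NC(=O)Nc4ccc(Cl)c(C(F)(F)F)c4)c3)cc2-c2ccncc2)c1`, compound 2 `COc1cc(Cl)cc(-c2nn(-c3cccc(NC(=O)c4cccc(C(F)(F)F)c4)c3)cc2-c2ccncc2)c1` and compound 3 `O=C(Nc1cccc(-n2cc(-c3ccncc3)c(-c3cc(O)cc(Cl)c3)n2)c1)Nc1ccc(Cl)c(Cl)c1`. In a functional assay on HCT-116 cells (Homo sapiens) for inhibition, read by sulforhodamine B assay, with a stated time of 48 h, tested at 0.1 uM (on this read-out higher numbers stand for a weaker effect at the one concentration tested and lower numbers for a stronger effect), compound 1 gives 97%, compound 2 gives 94% and compound 3 gives 102%. Compound 2 stands nearest to compound 1 and furthest from compound 3, yet both gaps lie within the scatter, so the three numbers cannot be told apart.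

Compound 4 `COc1cc(Cl)cc(-c2nn(-c3cccc(NC(=O)Nc4ccc(Cl)c(Cl)c4)c3)cc2-c2ccncc2)c1` differs from compound 2 in one place: (3,4-dichlorophenyl)amino in place of 3-(trifluoromethyl)phenyl on a carbonyl carbon. Among the measured compounds shown here, only one measured step bears on it. The change from compound 1 to compound 2 exchanged a carbamoyl-type arm for a carbonyl-type arm at the same place and gave a number 3 percentage points lower from compound 1 to compound 2 (within the scatter). For the measured compounds named here, compound 4 goes the other way, back to a carbamoyl-type arm, and its (3,4-dichlorophenyl)amino group is the one already present in compound 3, whose value is within the scatter of compound 2. Going by the values given here, no step in this small set moves beyond the scatter.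

Compound 4 is therefore expected to show a number 4 percentage points higher from compound 2 to compound 4 (within the scatter), a change not beyond the scatter. The estimate for compound 4 in this assay is 98%, with a range from 88% to 108%.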

Compound 4, a percentage reported as activity, at one concentration (the size of the read-out at that concentration, not a potency): 100%
Estimate against measurement, compound 4: 2 percentage points below; measured number inside the range.
By their numbers in this assay, from the lowest: compounds 2, 1, 4 and 3 (each within the scatter of the next).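

In this assay, among the compounds shown here, the exchange at the carbonyl carbon, now with a different aryl group and the amide-type nitrogen of the entering arm, gives a number 6 percentage points higher from compound 2 to compound 4 (within the scatter), while chloro in place of trifluoromethyl on an aromatic carbon, a change the earlier compounds did not isolate, gives a number 3 percentage points higher from compound 1 to compound 4 (within the scatter). Compound 4 also links to compound 3 through a single change, methyl in place of hydrogen on an oxygen on an aromatic ring, which gives a number 2 percentage points lower from compound 3 to compound 4 (within the scatter), so the arm, its ring substituent and the oxygen substituent have each now been varied alone, and none of these steps lies beyond the scatter. No measurement is available that would explain these results.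

The compounds shown leave open whether any change at these places can move the number beyond the scatter, since all four values remain within the scatter at the one concentration tested. As far as these compounds go, it also remains unknown what an amine or a carboxylic acid on the ring of the arm, or a longer chain in place of the methyl on the oxygen, would do in this assay.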